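Methyl on the Phenoxy Ring: Cytotoxicity Expectation for Compound 3

The source may report more compounds than this note shows. Statements on the series, on what has been measured and on what is new or still open speak of the compounds shown alone.

Among the measured compounds shown here, compound 2 `COc1ccnc(Nc2ccc(Cl)c(Oc3ccccc3)c2)n1` gives 38000 nM in an ADME assay on MT2 cells (Homo sapiens) for cytotoxicity (on this read-out higher numbers stand for lower toxicity in this test and lower numbers for higher toxicity in this test), the highest of the two numbers measured so far. Its nearest neighbour is compound 1 `C/C=C/COc1cc(Nc2nccc(OC)n2)ccc1Cl`, which in this assay gives 17000 nM; the step of a 2.2-fold higher number from compound 1 to compound 2 (0.35 log units; beyond the scatter) accompanied phenyl in place of but-2-en-1-yl on an oxygen on an aromatic ring. Compound 3 `COc1ccnc(Nc2ccc(Cl)c(Oc3ccccc3C)c2)n1` differs from compound 2 by methyl in place of hydrogen on an aromatic carbon, placed on an aromatic carbon of a six-membered aromatic ring of carbon only, ortho to a large group. For the measured compounds named here, no measured step covers a methyl in place of hydrogen; the one measured step concerned the whole group on the oxygen, and it was modest. Compound 3 is therefore expected to show no step beyond the scatter, a 1.2-fold lower number from compound 2 to compound 3 (0.07 log units; within the scatter), and its value in this assay is estimated at 32000 nM, with a range from 15000 nM to 70000 nM.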

Compound 3, half-maximal cytotoxic concentration: 13000 nM
The estimate for compound 3 lay 2.5-fold (0.39 log units) above the measured number; measured number below the stated range.
By their numbers in this assay, from the lowest: compounds 3 and 1 (each within the scatter of the next); then compound 2.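

In this assay, a single methyl on an aromatic carbon of the phenoxy ring, ortho to a large group, proved enough to move the number beyond the scatter (a 2.9-fold lower number from compound 2 to compound 3 (0.47 log units; beyond the scatter)). The earlier compounds shown here showed a change only when the whole group on the oxygen was replaced, yet this one added carbon cancels the rise seen with phenyl: 2-methylphenyl and but-2-en-1-yl on the oxygen stay within the scatter of each other (a 1.3-fold lower number from compound 1 to compound 3 (0.12 log units; within the scatter)). No measurement at hand accounts for this step.

The compounds shown leave open whether a fluorine, a methoxy or an amine in the same place would lower the number as the methyl does. They also leave open whether a larger group there, such as an ethyl, would lower it further.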